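Swapping an Aryl Group on a Shared Core: Expected Cytotoxicity

The compounds below may be only part of what the source reports. "The series", "measured", "known", "first", "only" and "open" are said of these compounds alone.

Three measured compounds share one core and differ only in the group on a saturated ring carbon. Compound 1 `N#CC1=C(N)N(c2ccc(S(N)(=O)=O)cc2)C2=C(CCCC2)C1/C=C/c1ccccc1` carries 2-phenylethenyl there and, in a functional assay on Ehrlich cells (Mus musculus) for cytotoxicity, read by trypan blue exclusion, with a stated time of 2 h, tested at 10 ug/mL (a higher number here means a stronger effect of the compound at the concentration tested, a lower number a weaker effect), compound 1 gives 50%. Compound 2 `COc1ccccc1C1C(C#N)=C(N)N(c2ccc(S(N)(=O)=O)cc2)C2=C1CCCC2` carries 2-methoxyphenyl and gives 30%. Compound 3 `N#CC1=C(N)N(c2ccc(S(N)(=O)=O)cc2)C2=C(CCCC2)C1c1ccccc1Cl` carries 2-chlorophenyl and gives 0%. Compound 2 thus stands second of the three, below compound 1 by a number 20 percentage points lower from compound 1 to compound 2 (beyond the scatter) and above compound 3 by a number 30 percentage points lower from compound 2 to compound 3 (beyond the scatter).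

Compound 4 `N#CC1=C(N)N(c2ccc(S(N)(=O)=O)cc2)C2=C(CCCC2)C1c1ccc(Cl)cc1Cl` is not yet measured; it differs from compound 2 by 2,4-dichlorophenyl in place of 2-methoxyphenyl on a saturated ring carbon. The step that bears most directly on this is the one from methoxy to chloro on the aromatic carbon, which lowered the read-out by a number 30 percentage points lower from compound 2 to compound 3 (beyond the scatter); the larger step of a number 50 percentage points lower from compound 1 to compound 3 (beyond the scatter) also ends at a chlorophenyl with no activity. A further drop in this assay is therefore expected, because compound 3 gives 0%. The expected step is a number 25 percentage points lower from compound 2 to compound 4 (beyond the scatter). Compound 4 is estimated at 5%, with a range from 0% to 25%.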

Compound 4, a percentage reported as activity, at one concentration (the size of the read-out at that concentration, not a potency): 0%
Beside the measured number, compound 4's estimate is 5 percentage points above it; the range from low to high includes it.
By their numbers in this assay, from the lowest: compounds 3 and 4 (each within the scatter of the next); then compound 2; then compound 1.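

In this assay, the second chloro makes no visible difference: no change at the digits printed from compound 3 to compound 4 (within the scatter), although with compound 3 already at 0%, any further fall could not show in this read-out. Replacing either of the other two groups with 2,4-dichlorophenyl gives the same steps as the single chloro, a number 30 percentage points lower from compound 2 to compound 4 (beyond the scatter) and a number 50 percentage points lower from compound 1 to compound 4 (beyond the scatter), so both chlorophenyl groups in this set now go with no measurable effect at this saturated ring carbon. Nothing measured here explains these differences.

The compounds shown leave open whether an unsubstituted phenyl or a hydroxyphenyl on this carbon would keep any of the effect. They also leave open whether a saturated 2-phenylethyl chain would match the 2-phenylethenyl group of compound 1.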